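Adding a Nitrile to the Pyridine of Compound 3

The source may report more compounds than this note shows. Statements on the series, on what has been measured and on what is new or still open speak of the compounds shown alone.

This series was examined in a functional assay on MCF7 cells (Homo sapiens) for antiproliferative activity, read by MTT assay, with a stated time of 72 h; on this read-out higher numbers stand for weaker inhibition and lower numbers for stronger inhibition. Compound 1 `COc1ccc(-c2ccc3ncnc(NCCN4CCCCC4)c3c2)cc1C(N)=O` gives 39100 nM in this assay. Compound 2 `COc1ncc(-c2ccc3ncnc(NCCN4CCCCC4)c3c2)cc1C#N` gives 2740 nM. Compound 3 `COc1ccc(-c2ccc3ncnc(NCCN(C)C)c3c2)cn1` gives 2970 nM in this assay, the second highest of the three numbers; its value lies within the scatter of that of compound 2, while compound 1 stands far higher, beyond the scatter.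

Compound 4 `COc1ncc(-c2ccc3ncnc(NCCN(C)C)c3c2)cc1C#N` has not yet been measured. It differs from compound 3 in one place: cyano in place of hydrogen on an aromatic carbon. No single-point comparison between measured compounds is available, so the size of this step cannot be read from the data; compound 2 carries the same cyano group but also a different amine, and its value sits close to that of compound 3.

Compound 4 is therefore expected to give a value near that of compound 3, the step of a 1.4-fold lower number from compound 3 to compound 4 (0.13 log units; within the scatter) being estimated as small and not clearly beyond the scatter. The estimate for compound 4 in this assay is 2200 nM, with a range from 700 nM to 7000 nM.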

Compound 4, half-maximal inhibitory concentration: 3230 nM
For compound 4 the middle estimate is 1.5-fold (0.17 log units) below the measured one; the measured number falls inside the stated range.
By their numbers in this assay, from the lowest: compounds 2, 3 and 4 (each within the scatter of the next); then compound 1.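

In this assay, among the compounds shown here, the cyano group, on an aromatic carbon ortho to a methoxy group, gives a 1.1-fold higher number from compound 3 to compound 4 (0.04 log units; within the scatter) as the first single-change reading at this position, so with the dimethylamino side chain this change cannot be told from scatter. With the cyano group in place, the side chain change gives a 1.2-fold higher number from compound 2 to compound 4 (0.07 log units; within the scatter) and also stays within the scatter, so dimethylamino and piperidin-1-yl cannot be told apart in this pair. No measurement shown here offers an explanation for either result.

From the compounds shown here alone, it remains open whether other groups at this position, such as an amine or a carboxylic acid, would separate from hydrogen and cyano in this assay. Also open, going by these compounds, is whether a longer chain between the core and the dimethylamino group would change the number.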